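The compounds below may be only part of what the source reports. "The series", "measured", "known", "first", "only" and "open" are said of these compounds alone.

Compound 3 `CC(C)[C@H](NC(=O)COc1cccc2ccccc12)C(=O)N[C@@H](CC(=O)O)C(=O)COc1ccc(C(N)=O)cc1` carries a carbamoyl on the aromatic ring of its ether end. In a functional assay on Jurkat cells (Homo sapiens) (a higher number here means a weaker inhibitor, a lower number a stronger inhibitor), compound 3 gives > 100000 nM, which is a limit of the assay and not a number. Compound 1 `CC(C)[C@H](NC(=O)COc1cccc2ccccc12)C(=O)N[C@@H](CC(=O)O)C(=O)COc1ccc(C(F)(F)F)cc1` likewise reaches only a limit, > 100000 nM. Compound 2 `CC(C)[C@H](NC(=O)COc1cccc2ccccc12)C(=O)N[C@@H](CC(=O)O)C(=O)COc1cc(C(F)(F)F)cc(C(F)(F)F)c1` also reaches only a limit, > 100000 nM. Among the measured compounds shown here, the one step measured, a step that the two limits leave unreadable from compound 1 to compound 3, therefore cannot be read, as all three values sit at the limit of > 100000 nM in this assay, at which 3 of the 3 values shown sit. Compound 4 `CC(C)[C@H](NC(=O)COc1cccc2ccccc12)C(=O)N[C@@H](CC(=O)O)C(=O)COc1ccc(F)cc1` differs from compound 3 in one place: fluoro in place of carbamoyl on an aromatic carbon. For the measured compounds named here, no measured step bears on this change; the series shows only that three neighbours stop at the same limit. Compound 4 is therefore expected to give about 150000 nM, between 30000 nM and 1000000 nM, most probably again a limit, which means an estimated step that the limit leaves unreadable from compound 3 to compound 4 that cannot be told from none.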

Compound 4, half-maximal inhibitory concentration: > 100000 nM
Compound 4 was reported as a limit; the forecaster's own chance of this, stated with the estimate: 85%; the middle value does not contradict the limit.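

Neither new step, from compound 3 to compound 4 or from compound 1 to compound 4, can be read, as compound 4 also stops at a limit: the limit of > 100000 nM in this assay, at which 4 of the 4 values shown sit. The compounds shown leave open whether any of these ring groups alters inhibition in this assay at all.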